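Sulfonamide series: naphthyl to 4-nitrophenyl on the sulfonamide nitrogen

The source may report more compounds than this note shows. Statements on the series, on what has been measured and on what is new or still open speak of the compounds shown alone.

Two compounds share the core and differ only in the aryl group on the sulfonamide nitrogen. Compound 1 `O=S(=O)(Nc1cccc2ccccc12)c1ccc2nc(-c3ccccc3)c(-c3ccccc3)nc2c1` gives 100% in an ADME assay on the whole organism for pharmacokinetics, with Homo sapiens as the target; a higher number here means that a larger share of the oral dose reaches the circulation, a lower number that a smaller share of the oral dose reaches the circulation; compound 2 `O=S(=O)(Nc1ccc2ccccc2c1)c1ccc2nc(-c3ccccc3)c(-c3ccccc3)nc2c1` gives 100% in this assay. Going by the values given here, the step of no change at the digits printed from compound 1 to compound 2 (within the scatter) shows that moving the attachment point around the naphthalene leaves the read-out unchanged, and compound 1 stands level with compound 2 on the numbers so far.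

Compound 3 `O=[N+]([O-])c1ccc(NS(=O)(=O)c2ccc3nc(-c4ccccc4)c(-c4ccccc4)nc3c2)cc1` is not yet measured. Against compound 1 the difference is 4-nitrophenyl in place of naphthalen-1-yl on a sulfonamide nitrogen. Among the compounds with values here, no measured step swaps a naphthyl for a nitro-bearing phenyl, so the only guide is that both measured compounds sit at the top of the scale and the one aryl variation tested, no change at the digits printed from compound 1 to compound 2 (within the scatter), moved nothing. The step of a number 15 percentage points lower from compound 1 to compound 3 (beyond the scatter) is therefore expected to be small or absent. The estimate for compound 3 is 85%, with a range from 50% to 100%.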

Compound 3, oral bioavailability: 87.6%
Compound 3: middle estimate off by 2.6 percentage points, on the low side, and the stated range covers the measured number.
By their numbers in this assay, from the lowest: compound 3; then compounds 1 and 2 (each within the scatter of the next).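

In this assay the aryl group on the sulfonamide nitrogen does affect the read-out: 4-nitrophenyl gives a number 12.4 percentage points lower from compound 1 to compound 3 (beyond the scatter) and a number 12.4 percentage points lower from compound 2 to compound 3 (beyond the scatter) in a series where the two naphthyl groups could not be told apart. The position thus responds to a change of aryl type, not to a shift of attachment point, and the step remains modest, leaving a high share of the oral dose reaching the circulation. Nothing available explains the lower number.

This single step removes one aromatic ring and brings in the nitro group together, so the two changes cannot be separated. An unsubstituted phenyl would part them, and a phenyl carrying an amine or a carboxylic acid would show whether other groups on that ring give a similar step.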